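Moving the Chlorine on the Phenyl Ring

The compounds below may be only part of what the source reports. "The series", "measured", "known", "first", "only" and "open" are said of these compounds alone.

This account follows two measured compounds and one awaiting measurement. Compound 1 `Clc1ccc(-c2cc(-c3ccsc3)nc(-c3ccccc3Cl)c2)o1` was tested in an assay on isolated protein for inhibition of DNA topoisomerase 1 (Homo sapiens), tested at 100 uM (a lower number here means a weaker effect, a higher number a stronger effect of the compound at the concentration tested), where compound 1 gives 0%. Compound 2 `Clc1ccc(-c2cc(-c3ccoc3)cc(-c3ccsc3)n2)cc1` was run in the same test, and in this assay compound 2 gives 0%. Compound 1 thus stands level with compound 2 at the digits reported, with no difference beyond the usual scatter. Within the data shown here, no single-change step between measured compounds is available to calibrate the next move. The unmeasured compound 3 `Clc1cccc(-c2cc(-c3ccc(Cl)o3)cc(-c3ccsc3)n2)c1` differs from compound 1 by one change: 3-chlorophenyl in place of 2-chlorophenyl on an aromatic carbon The two compounds have the same atoms, joined differently. Among the measured compounds shown here, because compound 1 gives 0% and compound 2 gives 0% in this assay, with no measured step suggesting otherwise, the expected step for compound 3 is no change at the digits printed from compound 1 to compound 3 (within the scatter), none beyond the scatter. For compound 3 the estimate in this assay is 0%, ranging from 0% to 10%.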

Compound 3, a percentage reported as inhibition, at one concentration (the size of the read-out at that concentration, not a potency): 0%
For compound 3 middle estimate and measured number coincide at the digits printed; the measured number falls inside the stated range.
By their numbers in this assay, from the lowest: compounds 1, 2 and 3 (each within the scatter of the next).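

Among these compounds, this is the first step measured at a single position: in this assay, 3-chlorophenyl in place of 2-chlorophenyl on an aromatic carbon gives no change at the digits printed from compound 1 to compound 3 (within the scatter) at the tested concentration. Relocating the chlorine on this phenyl ring, which sits next to the ring nitrogen, therefore does not produce a detectable effect in this test. Since both compounds read zero, the step cannot show whether either chlorine placement is better tolerated. No measured evidence is available to account for this result.

The compounds shown leave open whether replacing the chlorine with an amine or a carboxylic acid would produce any inhibition in this assay. They also leave open whether the same chlorine move would matter on a compound with a nonzero read-out.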